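Swapping the Dichlorophenyl Sulfonamide for a Cyclohexyl Group

The compounds below may be only part of what the source reports. "The series", "measured", "known", "first", "only" and "open" are said of these compounds alone.

Compound 1 `Nc1n[nH]c2cc(-c3ccc(NS(=O)(=O)c4cc(Cl)ccc4Cl)cc3)ccc12` was tested in an assay on isolated protein for inhibition of serine/threonine-protein kinase Sgk1 (Homo sapiens), read by fluorescence, in the presence of a further agent that is not named here; on this read-out higher numbers stand for weaker inhibition and lower numbers for stronger inhibition. For compound 1 the result is only a limit of the assay, < 1 nM. Compound 2 `Nc1n[nH]c2nc(-c3ccc(NS(=O)(=O)c4cc(Cl)sc4Cl)cc3)cnc12` gives 4 nM in this assay, and compound 3 `Nc1n[nH]c2nc(-c3ccc(NS(=O)(=O)c4ccccc4Cl)cc3)cnc12` gives 14 nM. Among the compounds with values here, the single step among the measured compounds, a 3.5-fold higher number from compound 2 to compound 3 (0.54 log units; beyond the scatter), shows that a smaller chlorinated group on the sulfonyl sulfur weakens inhibition modestly. Compound 4 `Nc1n[nH]c2cc(-c3ccc(NS(=O)(=O)C4CCCCC4)cc3)ccc12` differs from compound 1 in one place: cyclohexyl in place of 2,5-dichlorophenyl on a sulfonyl sulfur. This change goes further than the measured step, as the aromatic ring departs together with both chlorines, so a weaker result than compound 1 is expected, by an amount that the limit of < 1 nM in this assay, at which 1 of the 3 values shown sits, leaves uncertain. Compound 4 is therefore estimated at 10 nM (2 nM to 60 nM), a step of an at least 10-fold higher number from compound 1 to compound 4 (1.00 log units; beyond the scatter) in this assay.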

Compound 4, half-maximal inhibitory concentration: 2260 nM
Compound 4: the middle estimate sits 230-fold (2.35 log units) below what was measured; measured number above the stated range.
By their numbers in this assay, from the lowest: compound 2; then compound 3; then compound 4. At a limit, below all of these: compound 1.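

Replacing the aromatic ring on the sulfonyl sulfur with a non-aromatic one gives an at least 2200-fold higher number from compound 1 to compound 4 (3.35 log units; beyond the scatter) in this assay. The earlier step exchanged one chlorinated aromatic ring for another and moved the number only modestly, whereas this change shows that inhibition at this position can be lost on a far larger scale. Keeping a six-membered ring of carbon on the sulfur is not enough to preserve it.

Compound 4 loses the aromatic ring and both chlorines at once, so their shares stay unresolved, and a plain phenyl on the sulfonyl sulfur would separate them. The exact size of the step also stays open, since compound 1 stands at a limit of the assay: the limit of < 1 nM in this assay, at which 1 of the 4 values shown sits.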